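A few compounds are considered here, and "the series" means these few. Any claim that something is new, unique, unknown or untested is made for them only; others in the source may bear on it.

Compound 1 `COc1ccc(/C=N/c2c(C#N)ncn2-c2ccc(F)cc2)cc1` is measured in a functional assay on HT-29 cells (Homo sapiens) for antiproliferative activity, read by MTT assay, with a stated time of 48 h (a higher number here means a weaker inhibitor, a lower number a stronger inhibitor), and gives 19400 nM. Compound 2 `CC(C)c1ccc(/C=N/c2c(C#N)ncn2-c2ccc(F)cc2)cc1` yields only a limit of this assay, > 25000 nM, which is the limit described as the limit of > 25000 nM in this assay, at which 1 of the 3 values shown sits. The change between them is isopropyl in place of methoxy on an aromatic carbon, and the measured step is an at least 1.2-fold higher number from compound 1 to compound 2 (0.11 log units; that floor lies within the scatter). Compound 3 `COc1ccc(C2N=C(C(N)=O)c3ncn(-c4ccc(F)cc4)c3N2)cc1` carries a different core; in this assay compound 3 gives 11000 nM. The difference between the two cores is not broken down here. Compound 4 `CC(C)c1ccc(C2N=C(C(N)=O)c3ncn(-c4ccc(F)cc4)c3N2)cc1` has not been measured; it differs from compound 3 by isopropyl in place of methoxy on an aromatic carbon, the same change as that from compound 1 to compound 2. A step of a 2.0-fold higher number from compound 3 to compound 4 (0.30 log units; within the scatter) is therefore expected, resting on the measured step of an at least 1.2-fold higher number from compound 1 to compound 2 (0.11 log units; that floor lies within the scatter). For compound 4 the estimate in this assay is 22000 nM, with a range from 9000 nM to 60000 nM.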

Compound 4, half-maximal inhibitory concentration: 11000 nM
For compound 4 the middle estimate is 2.0-fold (0.30 log units) above the measured one; low and high end bracket the measured number.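

On the core of compound 3, in this assay, the change from 4-methoxyphenyl to 4-isopropylphenyl gives no change at the digits printed from compound 3 to compound 4 (within the scatter). Set beside the step on the core of compound 1, the result reads: the same change on two cores in this assay, an at least 1.2-fold higher number (0.11 log units; that floor lies within the scatter) from compound 1 to compound 2 and no change at the digits printed (within the scatter) from compound 3 to compound 4; the limit leaves it open whether they differ. The step on the core of compound 3 can thus be read, but whether the change carries over unaltered between the two cores stays undecided, as compound 2 gives only a limit of the assay: the limit of > 25000 nM in this assay, at which 1 of the 4 values shown sits.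

The compounds shown leave open how an amine, a carboxylic acid or a longer chain at this place would read on either core. They also leave open whether the two cores would part or agree outside this assay.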